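Ethoxy for Fluoro on a Carboxy-Bearing Core

The source may report more compounds than this note shows. Statements on the series, on what has been measured and on what is new or still open speak of the compounds shown alone.

Of the compounds shown here, three with a shared amide scaffold have been measured in a functional assay on Hep 3B2 cells (Homo sapiens) for antiproliferative activity, read by MTT assay, with a stated time of 24 h, tested at 11.11 ug/mL; a lower number here means a weaker effect, a higher number a stronger effect of the compound at the concentration tested. Compound 1 `Cc1c(C(=O)Nc2c(F)cc(-c3cccc(F)c3)cc2F)nc2ccc(F)cc2c1O` gives 31.3%. Compound 2 `CCOc1ccc2nc(C(=O)Nc3c(F)cc(-c4cccc(F)c4)cc3F)c(C)c(O)c2c1`, in which the change is ethoxy in place of fluoro on an aromatic carbon, gives 2.03%; the step of a number 29.3 percentage points lower from compound 1 to compound 2 (beyond the scatter). Compound 3 `Cc1c(C(=O)Nc2c(F)cc(-c3cccc(F)c3)cc2F)nc2ccc(F)cc2c1C(=O)O` differs from compound 1 by carboxy in place of hydroxy on an aromatic carbon, and compound 3 gives 26.3%, so the step of a number 5 percentage points lower from compound 1 to compound 3 (within the scatter). Compound 3 therefore stands with compound 1 rather than with compound 2.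

Compound 4 `CCOc1ccc2nc(C(=O)Nc3c(F)cc(-c4cccc(F)c4)cc3F)c(C)c(C(=O)O)c2c1` has not yet been measured in this assay. It is related to compound 3 as compound 2 is related to compound 1: the change is ethoxy in place of fluoro on an aromatic carbon, and the surroundings of the place are the same in both pairs, so this is the same change made on a different core. The two cores differ by carboxy in place of hydroxy on an aromatic carbon, a step that stayed within the usual scatter.

Because a number 29.3 percentage points lower from compound 1 to compound 2 (beyond the scatter), the expectation is that the same replacement on the core of compound 3 will cost a similar amount, and the step is estimated as a number 23.3 percentage points lower from compound 3 to compound 4 (beyond the scatter). For the measured compounds named here, this rests on the single earlier example alone, with nothing to show whether the carboxy core answers the ethoxy replacement differently. Compound 4 is thus expected to give about 3%, most likely between -10% and 16%.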

Compound 4, a percentage reported as inhibition, at one concentration (the size of the read-out at that concentration, not a potency): 33.2%
Compound 4: the middle estimate sits 30.2 percentage points below what was measured; the measured number lies above the stated range.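

In this assay, for the compounds shown here, the ethoxy replacement does not carry over from one core to the other: on the carboxy-bearing core it gives a number 6.9 percentage points higher from compound 3 to compound 4 (within the scatter), and the loss seen on the hydroxy-bearing core does not reappear: the same change on two cores in this assay, a number 29.3 percentage points lower (beyond the scatter) from compound 1 to compound 2 and a number 6.9 percentage points higher (within the scatter) from compound 3 to compound 4, 36.2 percentage points apart, beyond the scatter of two such steps The same dependence shows when the pairs are read the other way, since carboxy in place of hydroxy, which made no difference beyond the scatter with fluoro on the ring, gives a number 31.2 percentage points higher from compound 2 to compound 4 (beyond the scatter) with ethoxy there: the same change on two cores in this assay, a number 5 percentage points lower (within the scatter) from compound 1 to compound 3 and a number 31.2 percentage points higher (beyond the scatter) from compound 2 to compound 4, 36.2 percentage points apart, beyond the scatter of two such steps So in these four compounds the effect of each change depends on the other, and the single earlier step was no safe guide, but this is one comparison at one concentration, and it does not show why the two cores differ or whether the dependence extends to any other replacement.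

The compounds shown leave open whether the sharp drop belongs to ethoxy specifically on the hydroxy-bearing core, or would also appear with a methoxy or a longer chain such as propoxy at that place. They also leave open how an amine in place of the hydroxy or the carboxy would respond to the same fluoro-to-ethoxy replacement.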